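The source may hold more compounds than are shown below. What is called first, only, known or untested is meant among the compounds shown, and "the series" means these compounds.

Compound 1 `COc1ccc(-c2cc(-c3ccc(NS(C)(=O)=O)cc3)cnc2N)cn1` gives < 7 mL.min-1.g-1. Compound 2 `COc1ccc(-c2cc(-c3ccc(S(C)(=O)=O)c(F)c3)cnc2N)cn1` gives < 7 mL.min-1.g-1. Compound 3 `COc1ccc(-c2cnc(N)c(-c3ccc(OC)nc3)c2)cn1` gives 19.9 mL.min-1.g-1.

All three were tested in an in vitro ADME assay on microsomes from liver (Homo sapiens) for metabolic stability; a higher number here means faster removal of the compound, a lower number slower removal. The reading for compound 1 is a limit of the assay and not a number. Compound 1 sits at the limit of < 7 mL.min-1.g-1 in this assay, at which 2 of the 3 values shown sit. Going by the values given here, compound 3, the one compound with a numerical reading, stands higher than that limit.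

Compound 4 `COc1ccc(-c2cc(-c3ccc(C(N)=O)cc3)cnc2N)cn1` differs from compound 1 in a single place, (carbamoyl in place of methanesulfonamido on an aromatic carbon), that is, carbamoyl in place of methanesulfonamido on an aromatic carbon. Among the compounds with values here, no measured pair shows this change, so the expected step from compound 1 to compound 4 in this assay is a number no lower from compound 1 to compound 4 (the limit leaves the size open), which amounts to none beyond the usual scatter. Compound 4 is therefore expected to give 7 mL.min-1.g-1, with a likely range from 3.5 mL.min-1.g-1 to 15 mL.min-1.g-1.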

Compound 4, intrinsic clearance in microsomes: < 7 mL.min-1.g-1
Compound 4: only a limit was reported; the forecaster's own chance of this, stated with the estimate: 55%; the middle value lies on the limit itself.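

Going by these compounds alone, compound 1 and compound 4 each give only a limit in this assay, not a number, so no step between them can be read. Left open is how far apart the compounds at that limit truly lie in this assay: the limit of < 7 mL.min-1.g-1 in this assay, at which 3 of the 4 values shown sit.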